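The source may report more compounds than this note shows. Statements on the series, on what has been measured and on what is new or still open speak of the compounds shown alone.

Working notes on the series. Compound 1 `CC1CCN(c2c(S(=O)(=O)c3ccc(F)cc3)cnc3cc(Cl)ccc23)CC1` stands highest of the two numbers in hand: in an assay on isolated protein for displacement of a labelled ligand from metabotropic glutamate receptor 5 (Homo sapiens), with a stated time of 60 min, tested at 1 uM (a higher number here means more inhibition at the concentration tested (going by the name of the read-out), a lower number less inhibition), compound 1 gives 91%. Compound 2 `CC1CCN(c2c(S(=O)(=O)c3ccc(F)cc3)cnc3cc(F)ccc23)CC1` differs from it by fluoro in place of chloro on an aromatic carbon, and in this assay compound 2 gives 74.5%; the step between them is a number 16.5 percentage points lower from compound 1 to compound 2 (beyond the scatter), a modest loss. Compound 3 `COc1cccc(S(=O)(=O)c2cnc3cc(Cl)ccc3c2N2CCC(C)CC2)c1` is not yet measured. Compared with compound 1 the change is 3-methoxyphenyl in place of 4-fluorophenyl on a sulfonyl sulfur. For the measured compounds named here, no measured step touches the group on the sulfonyl sulfur; the only step available, a number 16.5 percentage points lower from compound 1 to compound 2 (beyond the scatter), concerns a different part of the core of compound 1 and so bears only indirectly, showing that one small change cost a modest amount. With nothing closer to go on, a step in this assay that stays within the scatter or falls somewhat below it is expected, the direction left open. Compound 3 is therefore estimated to give 80% in this assay, within a range of 55% to 95%. That estimate corresponds to an expected step of a number 11 percentage points lower from compound 1 to compound 3 (beyond the scatter).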

Compound 3, a percentage reported as inhibition, at one concentration (the size of the read-out at that concentration, not a potency): 93%
The estimate for compound 3 lay 13 percentage points below the measured number, and the stated range covers the measured number.
By their numbers in this assay, from the lowest: compound 2; then compounds 1 and 3 (each within the scatter of the next).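

For the compounds shown here, the first step at the sulfonyl sulfur, 3-methoxyphenyl in place of 4-fluorophenyl, comes out as a number 2 percentage points higher from compound 1 to compound 3 (within the scatter) in this assay, even though the entering group is larger and brings a hydrogen-bond acceptor that the leaving group lacks. This position therefore accepts this exchange with no visible change in the read-out, in contrast to the halogen exchange on the shared core, a number 16.5 percentage points lower from compound 1 to compound 2 (beyond the scatter), so in this small set a one-group change is not costly everywhere. No measurement in hand accounts for either step, so the result stands as an observation only.

The compounds shown leave open how far this acceptance extends: whether a carboxylic acid, an amine or a longer alkyl chain on the sulfonyl sulfur would keep the read-out at this level. A percentage at one concentration is also not a potency, so any difference in potency between compound 1 and compound 3 remains unresolved, as does whether the same exchange would behave alike on the fluoro core of compound 2.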